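This account rests on a few compounds, and the source may have more. Where it says the series, first, only, none or still open, it means among the compounds named here.

Measured in a functional assay on cells (Neutrophil, Homo sapiens) for inhibition, with a stated time of 10 min; a higher number here means a weaker inhibitor, a lower number a stronger inhibitor:

- Compound 1 `O=C(Nc1ccccc1)N1c2ccnn2CC1c1ccccc1`: > 1000 nM
- Compound 2 `O=C(Nc1ccccc1F)N1c2ccnn2CC1c1ccccc1`: > 1000 nM
- Compound 3 `CCOC(=O)c1cnn2c1N(C(=O)Nc1ccccc1)C(c1ccccc1)C2`: > 1000 nM

Each of these entries is a limit of the assay and not a number. The whole set sits at one mark, (the limit of > 1000 nM in this assay, at which 3 of the 3 values shown sit).

Compound 3 gives > 1000 nM, which is a limit. Compound 4 `CCOC(=O)c1cnn2c1N(C(=O)Nc1ccc(F)cc1)C(c1ccccc1)C2` differs from it in one place, (fluoro in place of hydrogen on an aromatic carbon), which turns phenyl to 4-fluorophenyl.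

Going by the values given here, two measured steps bear on this change. The closer one is a step that the two limits leave unreadable from compound 1 to compound 2, which is also fluoro in place of hydrogen on an aromatic carbon, but without the ethoxycarbonyl. The other is a step that the two limits leave unreadable from compound 1 to compound 3, which brings in the ethoxycarbonyl that compound 4 also carries. Neither step has a readable size, so they offer no direction and no magnitude for the new change. No step beyond the usual scatter is therefore expected, and the estimated step is a step that the limit leaves unreadable from compound 3 to compound 4. For compound 4 the estimated value in this assay is 2000 nM, with an expected range from 300 nM to 10000 nM.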

Compound 4, half-maximal inhibitory concentration: > 1000 nM
Compound 4 was reported as a limit; the forecaster's own chance of this, stated with the estimate: 70%; the middle value is on the limit's open side.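

Going by these compounds alone, compound 3 and compound 4 are both reported as limits in this assay, so the change to 4-fluorophenyl gives no step that can be read: the limit of > 1000 nM in this assay, at which 4 of the 4 values shown sit. The compounds shown leave open how strongly each one inhibits, and whether fluoro or ethoxycarbonyl changes inhibition at all.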